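Compound 3 to compound 4: removing one chloro

The source may report more compounds than this note shows. Statements on the series, on what has been measured and on what is new or still open speak of the compounds shown alone.

Values in a functional assay on MCF7 cells (Homo sapiens) for antiproliferative activity, read by MTT assay, with a stated time of 48 h (a higher number here means a weaker inhibitor, a lower number a stronger inhibitor), follow
compound 1 `Cc1ccc(C(=O)/C=C/c2cc(Cl)cc(Cl)c2Oc2c([N+](=O)[O-])cc(C(F)(F)F)cc2[N+](=O)[O-])cc1` gives 0.7 ug/mL
compound 2 `Cc1ccc(C(=O)/C=C/c2cccc(Cl)c2Oc2c([N+](=O)[O-])cc(C(F)(F)F)cc2[N+](=O)[O-])cc1` gives 0.03 ug/mL
compound 3 `O=C(/C=C/c1cc(Cl)cc(Cl)c1Oc1c([N+](=O)[O-])cc(C(F)(F)F)cc1[N+](=O)[O-])c1ccc(F)cc1` gives 5.02 ug/mL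

Compound 3 carries the highest number of the three and is therefore the weakest inhibitor here. It trails compound 1 by a modest gap (a 7.2-fold higher number from compound 1 to compound 3 (0.86 log units; beyond the scatter)) and compound 2 by a much wider one. Compound 4 `O=C(/C=C/c1cccc(Cl)c1Oc1c([N+](=O)[O-])cc(C(F)(F)F)cc1[N+](=O)[O-])c1ccc(F)cc1` has not been measured yet. It differs from compound 3 by one change (hydrogen in place of chloro on an aromatic carbon), which is hydrogen in place of chloro on an aromatic carbon. The same swap has been seen once, and it gave a large step beyond the scatter (a 23-fold lower number from compound 1 to compound 2 (1.37 log units; beyond the scatter)). The fluoro in place of methyl step above is the other relevant comparison, and it shows that the two series start at different levels. A single precedent may not carry over in full, so a clearly lower number is expected, though perhaps a smaller drop. The estimated change is a 14-fold lower number from compound 3 to compound 4 (1.16 log units; beyond the scatter) in this assay overall. For compound 4 the estimated value is 0.35 ug/mL within an expected range of 0.05 ug/mL to 2.5 ug/mL overall.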

Compound 4, half-maximal inhibitory concentration: 5.17 ug/mL
Estimate against measurement, compound 4: 15-fold (1.17 log units) below; measured number outside the range, above it.
By their numbers in this assay, from the lowest: compound 2; then compound 1; then compounds 3 and 4 (each within the scatter of the next).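

Removing this chloro has no single effect that carries from one core to the other: with fluoro in place of methyl, the step in this assay is within the scatter (a 1.0-fold higher number from compound 3 to compound 4 (0.01 log units; within the scatter)), while the same removal gave a large drop in the number on the methyl core. The size of this change therefore depends on the rest of the molecule: the same change on two cores in this assay, a 23-fold lower number (1.37 log units; beyond the scatter) from compound 1 to compound 2 and a 1.0-fold higher number (0.01 log units; within the scatter) from compound 3 to compound 4, 24-fold (1.38 log units) apart, beyond the scatter of two such steps. Seen from the other side, fluoro in place of methyl raises the number far more when this chloro is absent (a 170-fold higher number from compound 2 to compound 4 (2.24 log units; beyond the scatter)) than when it is present: the same change on two cores in this assay, a 7.2-fold higher number (0.86 log units; beyond the scatter) from compound 1 to compound 3 and a 170-fold higher number (2.24 log units; beyond the scatter) from compound 2 to compound 4, 24-fold (1.38 log units) apart, beyond the scatter of two such steps.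

The compounds shown leave open how other groups in place of the methyl or fluoro, such as methoxy or an amine, would behave with and without this chloro. They also cannot tell what lies behind the difference between the two cores.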